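The compounds below may be only part of what the source reports. "The series", "measured", "known", "first", "only" and "open" are said of these compounds alone.

Working notes on the chalcone series.

Compound 1 `CC1(C)Cc2c(OCc3ccccc3)ccc(C(=O)/C=C/c3ccccc3)c2O1` is the reference point. In a functional assay on B16 cells (Mus musculus) for antiproliferative activity, read by MTT assay, with a stated time of 48 h (on this read-out lower numbers stand for stronger inhibition and higher numbers for weaker inhibition), compound 1 gives 30300 nM. Compound 2 `CC1(C)Cc2c(OCc3ccccc3)ccc(C(=O)/C=C/c3ccc(F)cc3)c2O1` carries one change against compound 1, namely (fluoro in place of hydrogen on an aromatic carbon). In this assay compound 2 reaches only a limit of the assay and not a number, > 100000 nM. The step that results is an at least 3.3-fold higher number from compound 1 to compound 2 (0.51 log units; beyond the scatter), so the fluoro substitution moved the read-out toward weaker inhibition.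

Compound 3 `CC1(C)Cc2c(ccc(C(=O)/C=C/c3ccccc3)c2OCc2ccccc2)O1` contains the same atoms as compound 1, joined differently; the difference between the two cores is not broken down here. In this assay compound 3 also returns only a limit of the assay, > 100000 nM. Of the three measured values, two sit at this limit: the limit of > 100000 nM in this assay, at which 2 of the 3 values shown sit.

Compound 4 `CC1(C)Cc2c(ccc(C(=O)/C=C/c3ccc(F)cc3)c2OCc2ccccc2)O1` has not yet been measured. It differs from compound 3 by fluoro in place of hydrogen on an aromatic carbon. This is the same change that was made from compound 1 to compound 2, and the place it sits is described in the same words in both pairs, so it is taken as the same change.

For compound 4 the expected step is a step that the limit leaves unreadable from compound 3 to compound 4, because the step of an at least 3.3-fold higher number from compound 1 to compound 2 (0.51 log units; beyond the scatter) went toward weaker inhibition and compound 3 already sits at a limit, > 100000 nM. Compound 4 is therefore expected to give about 200000 nM in this assay, with the range estimated from 70000 nM to 600000 nM, and most likely to return only a limit again.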

Compound 4, half-maximal inhibitory concentration: > 100000 nM
Compound 4 ended at the assay's limit; the forecaster's own chance of this, stated with the estimate: 85%; the middle value does not contradict the limit.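

Compound 4, like compound 3, returns only a limit in this assay, so the step from phenyl to 4-fluorophenyl on this core cannot be read: the limit of > 100000 nM in this assay, at which 3 of the 4 values shown sit.

The compounds shown leave open whether that change shifts the read-out at all on the core of compound 3, and how far compound 3 and compound 4 lie beyond the limit.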